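From (2-oxopropyl)carbonyl to 3-methyl-1H-pyrazol-5-yl

This account rests on a few compounds, and the source may have more. Where it says the series, first, only, none or still open, it means among the compounds named here.

For the measured compounds named here, in a functional assay on HCT-116 cells (Homo sapiens) for cytotoxicity, read by MTT assay, with a stated time of 72 h (on this read-out lower numbers stand for stronger inhibition and higher numbers for weaker inhibition), compound 2 (`COc1ccc(/C=C/C(=O)CC(C)=O)cc1OC`) gives 4700 nM as the lower of the two numbers so far, against compound 1 (`COc1ccc(/C=C/c2cc(C)no2)cc1OC`) with 87400 nM as the higher. Compound 3 (`COc1ccc(/C=C/c2cc(C)n[nH]2)cc1OC`) carries 3-methyl-1H-pyrazol-5-yl in place of (2-oxopropyl)carbonyl on a double-bonded chain carbon bound to a double-bonded chain carbon. Going by the values given here, the only measured step bearing on this is the large 19-fold lower number from compound 1 to compound 2 (1.27 log units; beyond the scatter) with (2-oxopropyl)carbonyl entering in place of 3-methyl-1,2-oxazol-5-yl. Much of that step may be reversed now that (2-oxopropyl)carbonyl leaves again, although no compound with the entering group has been measured. The expected change is a 6.4-fold higher number from compound 2 to compound 3 (0.81 log units; beyond the scatter) in this assay toward a higher number. The estimated value for compound 3 is 30000 nM with 8000 nM and 100000 nM as its lower and upper ends.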

Compound 3, half-maximal inhibitory concentration: 51300 nM
For compound 3 the middle estimate is 1.7-fold (0.23 log units) below the measured one, within the range that was stated.
By their numbers in this assay, from the lowest: compound 2; then compounds 3 and 1 (each within the scatter of the next).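

In this assay, the ring 3-methyl-1H-pyrazol-5-yl does not match the open chain (2-oxopropyl)carbonyl at this position, with an 11-fold higher number from compound 2 to compound 3 (1.04 log units; beyond the scatter) as the step. The two rings cannot be told apart here, with a 1.7-fold lower number from compound 1 to compound 3 (0.23 log units; within the scatter) lying within the scatter, so among these three compounds only the open chain of compound 2 stands apart. No evidence at hand accounts for this difference.

As far as these compounds go, it remains open whether a shorter acetyl group in the same place keeps the lower number of compound 2. Also open, from the compounds shown here alone, is how a carboxylic acid would read there.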